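Side chain exchange on the carbonyl carbon

This account rests on a few compounds, and the source may have more. Where it says the series, first, only, none or still open, it means among the compounds named here.

In an ADME assay on HepG2 2.2.15 cells (Homo sapiens) for cytotoxicity (a higher number here means that more compound is tolerated, a lower number that less compound is tolerated), compound 1 `O=C(CCC1CCCCC1)OCCc1c(-c2ccccc2Cl)c2cc(Cl)ccc2[nH]c1=O` gives 160000 nM and compound 2 `O=C(COc1ccccc1)OCCc1c(-c2ccccc2Cl)c2cc(Cl)ccc2[nH]c1=O` gives 81000 nM. These two values lie within the scatter of each other, so compound 2 has no distinct standing in this pair.

Compound 3 `O=C(/C=C/c1cccc(C(F)(F)F)c1)OCCc1c(-c2ccccc2Cl)c2cc(Cl)ccc2[nH]c1=O` follows from compound 2 by one exchange (2-(3-(trifluoromethyl)phenyl)ethenyl in place of phenoxymethyl on a carbonyl carbon), with 2-(3-(trifluoromethyl)phenyl)ethenyl in place of phenoxymethyl on a carbonyl carbon. Among the measured compounds shown here, the only measured step that bears on this is a 2.0-fold lower number from compound 1 to compound 2 (0.30 log units; within the scatter), which also exchanges a group on the chain bound to the carbonyl carbon and stays within the scatter. It is a single step and a different exchange, and neither measured compound carries the entering group. No step beyond the scatter is therefore expected in this assay, and no direction is expected. The expected step is a 1.2-fold higher number from compound 2 to compound 3 (0.09 log units; within the scatter). For compound 3 the estimated value is 100000 nM, with an expected range of 40000 nM to 220000 nM.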

Compound 3, half-maximal cytotoxic concentration: > 1400000 nM
Compound 3 was reported as a limit (the forecaster's own chance of this, stated with the estimate: 15%); middle value at least 14-fold (1.14 log units) away from the limit.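

The group on the carbonyl carbon can move this assay beyond the scatter, which the pair of compound 1 and compound 2 did not show (exchange for 2-(3-(trifluoromethyl)phenyl)ethenyl: an at least 17-fold higher number from compound 2 to compound 3 (1.23 log units; beyond the scatter); against the 2-cyclohexylethyl side chain: an at least 8.7-fold higher number from compound 1 to compound 3 (0.94 log units; beyond the scatter)). The large step holds against phenoxymethyl and the at least modest one against 2-cyclohexylethyl, so the higher number appears with either of the two leaving groups shown. The result for compound 3 is a limit and not a number: (the limit of > 1400000 nM in this assay, at which 1 of the 3 values shown sits).

The entering group brings the ethenyl double bond and the trifluoromethyl group together, so the compounds shown do not separate their shares in the step. Also open, going by these compounds, is how a plain 2-phenylethenyl group, or an amine or a carboxylic acid on the same chain, would read here.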